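The source may hold more compounds than are shown below. What is called first, only, known or untested is meant among the compounds shown, and "the series" means these compounds.

Measured in a physicochemical assay for solubility, at pH 7.4; a lower number here means a less soluble compound, a higher number a more soluble compound:
- compound 1 `CC1(N)CN(c2c(F)cc3c(=O)c(C(=O)O)cn(C4CC4)c3c2F)C1`: 0.8 ug/mL; 15.3 ug/mL (2 entries)
- compound 2 `CN[C@H]1CN(c2cc3c(cc2F)c(=O)c(C(=O)O)cn3C2CC2)[C@@H]1C`: 9.2 ug/mL

Going by the values given here, compound 2 has only one number to stand on, since a further entry gave no single number. With so little data, its place is hard to judge. The next compound, compound 3 `CN[C@H]1CN(c2c(F)cc3c(=O)c(C(=O)O)cn(C4CC4)c3c2F)[C@@H]1C`, has not yet been measured. It differs from compound 2 by a fluoro in place of hydrogen on an aromatic carbon. Among the compounds with values here, no measured pair shows what such a swap does in this assay. Repeat entries can also disagree widely, as the several entries of compound 1 in this assay, 0.8 ug/mL; 15.3 ug/mL (2 entries) shows, so any forecast must stay broad. A small downward change, not beyond the usual scatter, is expected, and the estimated step is a 1.5-fold lower number from compound 2 to compound 3 (0.19 log units; within the scatter). The estimate for compound 3 is 6 ug/mL, with an expected range from 1.5 ug/mL to 24 ug/mL.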

Compound 3, solubility: 13.1 ug/mL
The estimate for compound 3 lay 2.2-fold (0.34 log units) below the measured number, and the stated range covers the measured number.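

The first pair differing in one place in this assay shows a 1.4-fold higher number from compound 2 to compound 3 (0.15 log units; within the scatter) when a fluoro replaces hydrogen on this aromatic carbon, ortho to a fused ring and meta to a fluoro group. At this position, then, this one pair gives no effect of the swap that can be told apart from the ordinary spread of repeated measurements. Even that reading needs care, since compound 2 and compound 3 each offer a single number and repeat entries can lie far apart: the several entries of compound 1 in this assay, 0.8 ug/mL; 15.3 ug/mL (2 entries).

Still open, going by these compounds, is whether another group on this same carbon, such as chlorine, a methoxy or an amine, would give a step beyond the scatter. Also open, on these data alone, is whether the fluoro swap would give a similar step with a piperazine in place of the amine-bearing ring of compound 3.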